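The compounds below may be only part of what the source reports. "The series", "measured", "known", "first", "only" and "open" are said of these compounds alone.

Among the measured compounds shown here, in an assay on isolated protein for antagonist activity at prostaglandin E2 receptor EP1 subtype (Homo sapiens), read by reporter gene assay (on this read-out lower numbers stand for stronger inhibition and higher numbers for weaker inhibition), compound 2 `O=C(O)c1csc(-n2nc(C3=CCCC3)c3ccccc32)n1` gives 80 nM, the lowest of the two numbers recorded; the only other measured compound, compound 1 `O=C(O)c1csc(-n2nc(-c3ccccc3)c3cccnc32)n1`, gives 200 nM in this assay, a higher number by a margin that lies beyond the usual scatter of this read-out. Compound 1 and compound 2 differ from each other in more than one place, so their two values are set side by side without being read as one single step.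

Compound 3 `O=C(O)c1csc(-n2nc(N3CCCCC3)c3ccccc32)n1` is built from compound 2 by a single exchange: piperidin-1-yl in place of cyclopent-1-en-1-yl on an aromatic carbon. For the measured compounds named here, no measured pair in this set carries the same exchange, so no direct precedent for its size exists. Compound 3 is therefore expected to stay close to compound 2 in this assay, with a slight lean toward a higher number, the expected step being a 1.9-fold higher number from compound 2 to compound 3 (0.27 log units; within the scatter). The estimate for compound 3 in this assay is 150 nM, in a range from 50 nM to 500 nM.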

Compound 3, half-maximal inhibitory concentration: 16 nM
Beside the measured number, compound 3's estimate is 9.4-fold (0.97 log units) above it, outside the stated range (below it).
By their numbers in this assay, from the lowest: compound 3; then compound 2; then compound 1.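

In this assay, putting piperidin-1-yl in place of cyclopent-1-en-1-yl on this aromatic carbon gives a 5.0-fold lower number from compound 2 to compound 3 (0.70 log units; beyond the scatter), a step that lies beyond the scatter. Among the compounds shown here, this is the first reading of a single change in the set: compound 1 and compound 2 differ in more than one place, so only this pair shows that the group at this position can by itself move the number, and that a non-aromatic ring holding a nitrogen is accepted here. Nothing in the available data accounts for the size of this step.

The exchange alters ring size and the atom attached to the aromatic carbon together, and the compounds shown do not separate the two. On these data alone, it remains open how pyrrolidin-1-yl, cyclohexyl or morpholin-4-yl would read at this position.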